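From 3-chlorophenyl to 4-(trifluoromethyl)phenyl on an amide-type nitrogen

A few compounds are considered here, and "the series" means these few. Any claim that something is new, unique, unknown or untested is made for them only; others in the source may bear on it.

In a functional assay on BT-483 cells (Homo sapiens) for cytotoxicity, read by MTT assay, with a stated time of 24 h (on this read-out lower numbers stand for stronger inhibition and higher numbers for weaker inhibition), compound 3 (`CCCNc1cc(-c2ccc(NC(=O)Nc3cccc(Cl)c3)cc2C(F)(F)F)ccn1`) gives 18500 nM and sits within the scatter of compound 1 (`CCNc1cc(-c2ccc(NC(=O)Nc3ccc(C(F)(F)F)cc3)cc2C(F)(F)F)ccn1`), which gives 16400 nM here. Compound 2 (`O=C(Nc1ccc(C(F)(F)F)cc1)Nc1ccc(-c2ccnc(NCC3CC3)c2)c(C(F)(F)F)c1`) gives > 30000 nM as a limit of the assay. Compound 4 (`CCCNc1cc(-c2ccc(NC(=O)Nc3ccc(C(F)(F)F)cc3)cc2C(F)(F)F)ccn1`) has 4-(trifluoromethyl)phenyl in place of 3-chlorophenyl on an amide-type nitrogen. For the measured compounds named here, the one measured step (an at least 1.8-fold higher number from compound 1 to compound 2 (0.26 log units; that floor lies within the scatter)) lies elsewhere, on the chain, and does not cover this exchange. Compound 1 already carries the entering group on that nitrogen, and its value (16400 nM) lies within the scatter of compound 3. No step beyond the scatter is therefore expected in this assay (an estimated 1.1-fold lower number from compound 3 to compound 4 (0.04 log units; within the scatter)). For compound 4 the estimated value is 17000 nM within an expected range of 9000 nM to 30000 nM for repeated measurements.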

Compound 4, half-maximal inhibitory concentration: 18800 nM
Compound 4: middle estimate off by 1.1-fold (0.04 log units), on the low side; the measured number falls inside the stated range.
By their numbers in this assay, from the lowest: compounds 1, 3 and 4 (each within the scatter of the next). At a limit, above all of these: compound 2.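

In this assay, 4-(trifluoromethyl)phenyl in place of 3-chlorophenyl on the amide-type nitrogen brings no change beyond the scatter: a 1.0-fold higher number from compound 3 to compound 4 (0.01 log units; within the scatter). On the saturated chain, methyl in place of hydrogen likewise stays within the scatter, a 1.1-fold higher number from compound 1 to compound 4 (0.06 log units; within the scatter), and ethyl in place of cyclopropyl offers only a floor, an at least 1.5-fold lower number from compound 2 to compound 4 (0.20 log units; that floor lies within the scatter). The value of compound 2 is a limit, not a number: the limit of > 30000 nM in this assay, at which 1 of the 4 values shown sits.

On these data alone, it remains open whether a carboxylic acid on the phenyl group at this amide-type nitrogen, or a longer saturated chain, would move the number beyond the scatter.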